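The source may hold more compounds than are shown below. What is called first, only, known or untested is meant among the compounds shown, and "the series" means these compounds.

Going by the values given here, in a physicochemical assay for lipophilicity, read by HPLC, measured as octanol-water partition, at pH 7.4 (a higher number here means a more lipophilic compound, a lower number a more polar compound), compound 1 `CC1(C)CO[C@@H]1CN([C@H](CCC(F)(F)F)C(N)=O)S(=O)(=O)c1ccc(Cl)cc1` gives 3.9, the second highest of the three numbers measured so far. Compound 2 `NC(=O)[C@@H](CCC(F)(F)F)N(CC1CCCC1)S(=O)(=O)c1ccc(Cl)cc1` gives 5.15, and compound 3 `NC(=O)[C@@H](CCC(F)(F)F)N(C[C@H]1CCCOC1)S(=O)(=O)c1ccc(Cl)cc1` gives 3.6. The step of a number 1.25 log units higher from compound 1 to compound 2 (beyond the scatter) is large, while the step of a number 0.30 log units lower from compound 1 to compound 3 (within the scatter) stays within the scatter. Compound 4 `NC(=O)[C@@H](CCC(F)(F)F)N(C[C@H]1CCO1)S(=O)(=O)c1ccc(Cl)cc1` differs from compound 1 in one place: oxetan-2-yl in place of 3,3-dimethyloxetan-2-yl on a saturated chain carbon bound to a sulfonamide nitrogen. Among the compounds with values here, none of the measured steps shows this change; the large steps of a number 1.25 log units higher from compound 1 to compound 2 (beyond the scatter) and a number 1.55 log units lower from compound 2 to compound 3 (beyond the scatter) both exchange the whole ring, so they give only indirect guidance. A modest downward step beyond the scatter is expected. Compound 4 is expected to give 3, within a range from 2.6 to 3.4. The expected step is a number 0.90 log units lower from compound 1 to compound 4 (beyond the scatter).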

Compound 4, distribution coefficient: 2.6
Compound 4: middle estimate off by 0.40 log units, on the high side; the range from low to high includes it.
By their numbers in this assay, from the lowest: compound 4; then compounds 3 and 1 (each within the scatter of the next); then compound 2.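

In this assay, going by these compounds alone, taking the methyl groups off the oxetane while keeping the four-membered ring gives a large drop (a number 1.30 log units lower from compound 1 to compound 4 (beyond the scatter)), the first step at this position that leaves the ring in place. Compound 4 also lies beyond the scatter below the other ring types (a number 1.00 log units lower from compound 3 to compound 4 (beyond the scatter); a number 2.55 log units lower from compound 2 to compound 4 (beyond the scatter)), whereas compound 1 and compound 3 stay within the scatter of each other. No measurement shown accounts for the size of these steps.

The compounds shown leave open how much of the drop a single methyl group on the oxetane would retain. They also leave open where an azetidin-2-yl group would fall at this position.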